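The source may hold more compounds than are shown below. What is called first, only, known or untested is meant among the compounds shown, and "the series" means these compounds.

Within the data shown here, compound 1 `COc1cc2nc(N3CCN(S(=O)(=O)c4ccc(I)cc4)CC3)nc(N)c2cc1OC` stands lowest of the two numbers measured so far: in a functional assay on PC-3 cells (Homo sapiens) for inhibition (on this read-out lower numbers stand for stronger inhibition and higher numbers for weaker inhibition), compound 1 gives 15000 nM. Among the measured compounds shown here, compound 2 `COc1cc2nc(N3CCN(S(=O)(=O)c4cc(Cl)ccc4Cl)CC3)nc(N)c2cc1OC` gives 60000 nM in this assay, and the single step measured at this place, a 4.0-fold higher number from compound 1 to compound 2 (0.60 log units; beyond the scatter), shows a modest loss on exchanging the aryl group. Compound 3 `COc1cc2nc(N3CCN(S(=O)(=O)c4cc(F)c(Cl)c(C(=O)O)c4)CC3)nc(N)c2cc1OC` differs from compound 1 by 3-carboxy-4-chloro-5-fluorophenyl in place of 4-iodophenyl on a sulfonyl sulfur. For the measured compounds named here, only that one modest step bears on it, so a shift of similar size toward weaker inhibition, or none beyond the scatter, is expected: a 1.7-fold higher number from compound 1 to compound 3 (0.22 log units; within the scatter). Compound 3 is therefore estimated at 25000 nM, between 8000 nM and 80000 nM.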

Compound 3, half-maximal inhibitory concentration: 56000 nM
For compound 3 the middle estimate is 2.2-fold (0.35 log units) below the measured one; low and high end bracket the measured number.
By their numbers in this assay, from the lowest: compound 1; then compounds 3 and 2 (each within the scatter of the next).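

In this assay, the step of a 3.7-fold higher number from compound 1 to compound 3 (0.57 log units; beyond the scatter) shows that a second, very different aryl group on the sulfonyl sulfur also gives weaker inhibition than 4-iodophenyl. The step of a 1.1-fold lower number from compound 2 to compound 3 (0.03 log units; within the scatter) leaves 3-carboxy-4-chloro-5-fluorophenyl and 2,5-dichlorophenyl indistinguishable, so 4-iodophenyl alone stands apart among these three groups. No evidence at hand explains this. The compounds shown leave open whether the iodine itself matters, since no other single substituent is compared with it. They also leave open how a plain phenyl, or a phenyl carrying an amine, would fare here.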